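A few compounds are considered here, and "the series" means these few. Any claim that something is new, unique, unknown or untested is made for them only; others in the source may bear on it.

Compound 2 `Cc1cc(C#N)cc(-c2c(C)nn(-c3nc(-c4ccc(Cl)c(Cl)c4)c(SC(C)C)s3)c2C(=O)O)c1` gives 4800 nM in a functional assay on BJAB cells (Homo sapiens) for antiproliferative activity, with a stated time of 4 days (on this read-out higher numbers stand for an effect only at larger amounts of compound and lower numbers for an effect already at smaller amounts), the lowest of the two numbers recorded so far, while compound 1 `Cc1nn(-c2nc(-c3ccc(Cl)c(Cl)c3)c(SC(C)C)s2)c(C(=O)O)c1-c1cccc(C(F)(F)F)c1` gives 22000 nM. Among the compounds with values here, the only measured step, a 4.6-fold lower number from compound 1 to compound 2 (0.66 log units; beyond the scatter), changed the same part of the molecule that is varied again here. Compound 3 `COc1cc(C#N)cc(-c2c(C)nn(-c3nc(-c4ccc(Cl)c(Cl)c4)c(SC(C)C)s3)c2C(=O)O)c1` differs from compound 2 by methoxy in place of methyl on an aromatic carbon. That earlier step was modest and concerned a different exchange, so it offers only a loose guide, and no shift beyond the scatter is anticipated. Compound 3 is therefore expected to show a step of no change at the digits printed from compound 2 to compound 3 (within the scatter). The estimate for compound 3 is 4800 nM, within 2000 nM to 12000 nM.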

Compound 3, half-maximal effective concentration: 5200 nM
Estimate against measurement, compound 3: 1.1-fold (0.03 log units) below; low and high end bracket the measured number.
By their numbers in this assay, from the lowest: compounds 2 and 3 (each within the scatter of the next); then compound 1.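

In this assay, methoxy and methyl on this aromatic carbon cannot be told apart, with a 1.1-fold higher number from compound 2 to compound 3 (0.03 log units; within the scatter). The 3-cyano-5-methoxyphenyl group also stands clear of 3-(trifluoromethyl)phenyl, with a 4.2-fold lower number from compound 1 to compound 3 (0.63 log units; beyond the scatter), so the difference first seen with compound 2 does not depend on the methyl group. Nothing available here accounts for either step. The compounds shown leave open whether an amine or a longer chain such as ethoxy at this position would give a similar number, and whether the cyano group itself matters.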